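The source may report more compounds than this note shows. Statements on the series, on what has been measured and on what is new or still open speak of the compounds shown alone.

Of the compounds shown here, two have been measured in a functional assay on A2780 cells (Homo sapiens) for inhibition, with a stated time of 72 h; a higher number here means a weaker inhibitor, a lower number a stronger inhibitor. Compound 1, `CCC1(CC)CC(C)(C)Oc2ccc(NC(=S)Nc3ccc(C(F)(F)F)cc3)cc21`, carries a thiourea linking two aromatic rings, one of which bears a trifluoromethyl; in this assay compound 1 gives 4700 nM. Compound 2, `CC1(C)CCOc2ccc(NC(=O)Nc3ccc(C(F)(F)F)cc3)cc21`, is the urea counterpart and lacks the ethyl groups of compound 1; in this assay compound 2 gives 5000 nM. For the measured compounds named here, these two values lie within the usual scatter of each other, so on the numbers so far compound 1 and compound 2 cannot be told apart, and no single-point step between them can be drawn, as they differ in more than one place.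

Compound 3, `CCC1(CC)CC(C)(C)Oc2ccc(NC(=S)Nc3ccc([N+](=O)[O-])cc3)cc21`, is the next compound to be measured. It differs from compound 1 in one place: nitro in place of trifluoromethyl on an aromatic carbon. Nothing in the two measured values speaks to this change, since both measured compounds carry the trifluoromethyl. Lacking any measured step that bears on it, the step expected here is a 1.1-fold higher number from compound 1 to compound 3 (0.03 log units; within the scatter), small and within the scatter, with no clear direction. Compound 3 is therefore expected to give about 5000 nM in this assay, within a range from 1500 nM to 15000 nM.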

Compound 3, half-maximal inhibitory concentration: 3690 nM
Compound 3: the middle estimate sits 1.4-fold (0.13 log units) above what was measured, and the stated range covers the measured number.
By their numbers in this assay, from the lowest: compounds 3, 1 and 2 (each within the scatter of the next).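

In this assay, the position on the aromatic ring para to a large group now has a comparison that changes one place only: nitro in place of trifluoromethyl gives a step (a 1.3-fold lower number from compound 1 to compound 3 (0.11 log units; within the scatter)) that leaves the two compounds indistinguishable. Compound 1 and compound 2 both carry trifluoromethyl and so could not speak to this position, whereas compound 3 shows that this group can be replaced by nitro, which brings hydrogen-bond acceptors that trifluoromethyl lacks, without a change that can be told from the scatter of the assay. No measurement of any property of these groups bears on this result, and the comparison therefore stays a plain observation without an explanation.

The compounds shown leave open whether a quite different group at this position, such as an amine, a carboxylic acid or a longer chain, would shift the number beyond the scatter. They also leave open what the thiourea and the ethyl groups each contribute on their own, as compound 1 and compound 2 differ in more than one place.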